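The source may hold more compounds than are shown below. What is called first, only, known or untested is meant among the compounds shown, and "the series" means these compounds.

Compound 1 `N#Cc1c(N2CCC(c3ccccc3)CC2)ccn2c(CC(F)(F)F)nnc12`: 277%
Compound 2 `CCCCc1nnc2c(C(F)(F)F)c(N3CCC(c4ccccc4)CC3)ccn12`: 364%
Compound 3 `Fc1ccc(C2CCN(c3ccn4c(CC5CC5)nnc4c3C(F)(F)F)CC2)c(F)c1`: 306%

In a functional assay on CHO cells for positive allosteric modulation of metabotropic glutamate receptor 2 (Homo sapiens), read by GTPgammaS binding, with a stated time of 30 min (on this read-out lower numbers stand for smaller maximal responses and higher numbers for larger maximal responses), compound 3 gives 306%, the second highest of the three numbers. Its nearest neighbour is compound 1, which sits lower by more than the usual scatter, and compound 2 sits higher, again beyond the scatter. Compound 4 `FC(F)(F)c1c(N2CCC(c3cccnc3)CC2)ccn2c(CC3CC3)nnc12` has not been measured. It differs from compound 3 in one place: pyridin-3-yl in place of 2,4-difluorophenyl on a saturated ring carbon. For the measured compounds named here, none of the measured compounds differs from another in a single place, so no measured step shows what this exchange does. The expected step of a number 26 percentage points lower from compound 3 to compound 4 (beyond the scatter) is a small drop, possibly no larger than the scatter. Compound 4 is therefore expected to reach about 280%, within a range from 200% to 360%.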

Compound 4, largest response reached (Emax), in percent of the reference or control that the assay uses: 268%
Compound 4: middle estimate off by 12 percentage points, on the high side, within the range that was stated.
By their numbers in this assay, from the lowest: compounds 4 and 1 (each within the scatter of the next); then compound 3; then compound 2.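

In this assay, placing pyridin-3-yl instead of 2,4-difluorophenyl on this saturated ring carbon gives a number 38 percentage points lower from compound 3 to compound 4 (beyond the scatter) and so offers the first single-change reading. It shows that the maximal response depends on the aromatic ring held at this position. The response does not vanish with this exchange, since compound 4 still reaches 268% in this test.

A 4-fluorophenyl or pyridin-4-yl group at this place could show whether the fluorines or the ring nitrogen matter more. Nothing at hand explains the drop itself.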